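Pyridin-4-yl in Place of Phenyl on Two Related Cores

This account rests on a few compounds, and the source may have more. Where it says the series, first, only, none or still open, it means among the compounds named here.

Four closely related compounds are considered, three measured and one still awaiting its number in an assay on isolated protein for displacement of a labelled ligand from 5-hydroxytryptamine receptor 6 (Homo sapiens), read by scintillation counting, with a stated time of 1 h; on this read-out lower numbers stand for stronger inhibition and higher numbers for weaker inhibition. Compound 1 `O=S(=O)(c1ccccc1)n1ccc2cc(-c3ccccc3)ccc21` gives 558 nM in this assay. Compound 2 `O=S(=O)(c1ccccc1)n1ccc2cc(-c3ccncc3)ccc21` differs from compound 1 in one place, (pyridin-4-yl in place of phenyl on an aromatic carbon), and in this assay compound 2 gives 409 nM. This change made the step of a 1.4-fold lower number from compound 1 to compound 2 (0.13 log units; within the scatter), so the two values cannot be told apart with confidence.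

Compound 3 `O=S(=O)(c1ccccc1)n1ccc2ccc(-c3ccccc3)cc21` is built from the same atoms as compound 1, joined differently; the difference between the two cores is not broken down here. In this assay compound 3 gives 178 nM, the lowest of the three numbers, and its steps to compound 2 and to compound 1 both lie beyond the scatter.

Compound 4 `O=S(=O)(c1ccccc1)n1ccc2ccc(-c3ccncc3)cc21` has not yet been measured in this assay. It differs from compound 3 by pyridin-4-yl in place of phenyl on an aromatic carbon, the same change as that from compound 1 to compound 2, made at a place described in the same words. The expected step of a 1.4-fold lower number from compound 3 to compound 4 (0.14 log units; within the scatter) is small, because the same change earlier made a 1.4-fold lower number from compound 1 to compound 2 (0.13 log units; within the scatter), a step that did not leave the scatter. Compound 4 is therefore expected to give about 130 nM in this assay, with an estimated range from 60 nM to 300 nM.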

Compound 4, inhibition constant: 38 nM
The estimate for compound 4 lay 3.4-fold (0.53 log units) above the measured number, outside the stated range (below it).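

In this assay, pyridin-4-yl in place of phenyl on an aromatic carbon gave a 4.7-fold lower number from compound 3 to compound 4 (0.67 log units; beyond the scatter), a step that, unlike the earlier one on the core of compound 1, lies beyond the scatter. For the compounds shown here, the same change therefore did not bring a step of the same size on the two cores, and the gap between the two steps is itself larger than the scatter allows: the same change on two cores in this assay, a 1.4-fold lower number (0.13 log units; within the scatter) from compound 1 to compound 2 and a 4.7-fold lower number (0.67 log units; beyond the scatter) from compound 3 to compound 4, 3.4-fold (0.54 log units) apart, beyond the scatter of two such steps This shows that the size of the step cannot simply be carried from one core to the other, but it does not show why the cores differ, and with only one pair on each core it gives no general rule for how this change behaves on further cores.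

The compounds shown leave open whether the larger step on the core of compound 3 is particular to pyridin-4-yl or would also appear with another group at the same place, such as an amine or a carboxylic acid. They also leave open how the change would behave on a core carrying something other than the phenyl on the sulfonyl group, for instance a methyl group or a longer chain.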